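Replacing 2-oxopiperidin-1-yl with 2-amino-1,3-thiazol-5-yl

This account rests on a few compounds, and the source may have more. Where it says the series, first, only, none or still open, it means among the compounds named here.

Of the compounds shown here, three sharing one core have been measured in an ADME assay on microsomes from liver (Mus musculus) for metabolic stability; a higher number here means that the compound lasts longer, a lower number that the compound disappears faster. Compound 1 (`CC(C)C(Cc1ncc[nH]1)c1ccc(-c2ccc3cccc(F)c3c2)[nH]c1=O`) reports only a limit (< 0.0667 h). Compound 2 (`CC(C)C(c1ccc(-c2ccc3cccc(F)c3c2)[nH]c1=O)N1CCCCC1=O`) gives 0.0967 h as the lowest actual number, while compound 3 (`CCC(CC)(c1nnc[nH]1)c1ccc(-c2ccc3cccc(F)c3c2)[nH]c1=O`) gives 0.447 h, a gap beyond the scatter. Compound 4 (`CC(C)C(c1cnc(N)s1)c1ccc(-c2ccc3cccc(F)c3c2)[nH]c1=O`) carries 2-amino-1,3-thiazol-5-yl in place of 2-oxopiperidin-1-yl on a saturated chain carbon bound to an aromatic carbon and a saturated chain carbon. Among the compounds with values here, the only measured step at this place is a different replacement, an at least 1.4-fold higher number from compound 1 to compound 2 (0.16 log units; that floor lies within the scatter), and it starts from the limit of < 0.0667 h in this assay, at which 1 of the 3 values shown sits. Within the data shown here, with only that step to go on, no shift beyond the scatter is expected, and the estimated move is small (a 1.2-fold higher number from compound 2 to compound 4 (0.09 log units; within the scatter)). For compound 4 the estimated half-life is 0.12 h (expected range 0.06 h to 0.3 h).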

Compound 4, half-life: 0.08 h
The estimate for compound 4 lay 1.5-fold (0.18 log units) above the measured number; low and high end bracket the measured number.
By their numbers in this assay, from the lowest: compounds 4 and 2 (each within the scatter of the next); then compound 3. At a limit, below all of these: compound 1.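

In this assay, swapping a non-aromatic six-membered ring for an aromatic five-membered one on this saturated chain carbon leaves the two compounds within the scatter: a 1.2-fold lower number from compound 2 to compound 4 (0.08 log units; within the scatter). This change of ring type and of hydrogen-bond donor count therefore gives no readable shift at this position. The other new step gives only a floor, an at least 1.1-fold higher number from compound 1 to compound 4 (0.07 log units; that floor lies within the scatter), and it rests on a limit: the limit of < 0.0667 h in this assay, at which 1 of the 4 values shown sits.

On these data alone, whether a carboxylic acid or a morpholine ring on this carbon would move the half-life beyond the scatter remains open. So does the part played by the amino group of 2-amino-1,3-thiazol-5-yl.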